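The source may report more compounds than this note shows. Statements on the series, on what has been measured and on what is new or still open speak of the compounds shown alone.

Measured in an ADME assay on J774 cells (Mus musculus) for cytotoxicity; a higher number here means that more compound is needed for the effect, a lower number that less compound is needed:
compound 1 `COc1ccc2[nH]c(C)c(Cc3ccccc3)c(=O)c2c1`: > 23700 nM, a limit of the assay.
compound 2 `Cc1[nH]c2ccc(Cl)cc2c(=O)c1Cc1ccccc1`: > 35200 nM, a limit of the assay.
compound 3 `COc1cccc2[nH]c(C)c(Cc3ccccc3)c(=O)c12`: 11200 nM.

Going by the values given here, compound 3 holds the only number; the two further values are limits. Compound 1 sits at the limit of > 23700 nM in this assay, at which 1 of the 3 values shown sits. Compound 2 sits at the limit of > 35200 nM in this assay, at which 1 of the 3 values shown sits. From compound 1 to compound 2 the change is chloro in place of methoxy on an aromatic carbon, and the step that the two limits leave unreadable from compound 1 to compound 2 cannot be sized from two limits. Compound 3 and compound 1 have the same atoms joined differently; the difference between the two cores is not broken down here. Compound 4 `Cc1[nH]c2cccc(Cl)c2c(=O)c1Cc1ccccc1` is not yet measured in this assay. From compound 3 it differs by chloro in place of methoxy on an aromatic carbon, the same kind of change as from compound 1 to compound 2, but here the place is ortho to a fused ring and meta to a fused ring, not meta and para. Among the compounds with values here, no step of this kind is readable among the measured pairs. Compound 4 is therefore expected to stay near compound 3. The expected step is a 1.3-fold higher number from compound 3 to compound 4 (0.13 log units; within the scatter), resting on compound 3 at 11200 nM. For compound 4 the estimate is 15000 nM, expected between 5000 nM and 45000 nM.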

Compound 4, half-maximal effective concentration: > 35200 nM
Compound 4: a limit, no number; the forecaster's own chance of this, stated with the estimate: 40%; middle value at least 2.3-fold (0.37 log units) from the limit.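

In this assay, chloro in place of methoxy, ortho to a fused ring and meta to a fused ring, gives an at least 3.1-fold higher number from compound 3 to compound 4 (0.49 log units; beyond the scatter) as a step with only a lower bound. From the compounds shown here alone, compound 4 gives > 35200 nM, which is a limit of the assay and not a number, so the full size of the step stays unknown. The same change from compound 1 to compound 2 joins two limits and cannot be read, so the notes do not show whether the step carries over in size from one core to the other.

Only methoxy and chloro are compared at these places on the shared core. Going by these compounds, how an amine, a carboxylic acid or a longer chain there would read in this assay remains open.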